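One stereocentre changed on a compound at the assay limit

The source may hold more compounds than are shown below. What is called first, only, known or untested is meant among the compounds shown, and "the series" means these compounds.

Measured compounds:
compound 1, `CC[C@@H]1C[C@@H](O)C/C=C(/C)[C@H]2c3cc(OCc4ccccc4)c(OCc4ccccc4)cc3CCN12`: > 20000 nM
compound 2, `CCC[C@@H]1CC(=O)C/C=C(/CC)[C@H]2c3cc(OCc4ccccc4)c(OCc4ccccc4)cc3CCN12`: > 20000 nM

In an ADME assay on RWPE-1 cells (Homo sapiens) for inhibition, read by MTT assay, with a stated time of 24 h (on this read-out higher numbers stand for weaker inhibition and lower numbers for stronger inhibition), compound 1 gives > 20000 nM, which is a limit of the assay and not a number. Compound 2 gives > 20000 nM in this assay, likewise only a limit. Compound 1 therefore stands at the limit of > 20000 nM in this assay, at which 2 of the 2 values shown sit, and nothing finer separates it from compound 2.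

Compound 3, `CC[C@@H]1C[C@H](O)C/C=C(/C)[C@H]2c3cc(OCc4ccccc4)c(OCc4ccccc4)cc3CCN12`, has not been measured. It differs from compound 1 as follows: the two compounds have the same atoms and bonds and differ only in configuration as drawn: 1 of 4 stereo elements differ; a stereocentre at a saturated ring carbon is drawn S in compound 1 and R in compound 3. For the measured compounds named here, no step between measured compounds of this kind is available, so the size of the change cannot be read from data. Because compound 1 sits at the limit of > 20000 nM in this assay, at which 2 of the 2 values shown sit, the step to compound 3 in this assay is expected to be none beyond the scatter, most likely ending in another limit. Compound 3 is estimated at 30000 nM, with a range from 10000 nM to 100000 nM. The step that the limit leaves unreadable from compound 1 to compound 3 is thereby expected to stay within the scatter.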

Compound 3, half-maximal inhibitory concentration: > 20000 nM
Compound 3: a limit, no number (the forecaster's own chance of this, stated with the estimate: 85%); the middle value is on the limit's open side.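

No size can be read for the step from compound 1 to compound 3, because both values are limits and not numbers: the limit of > 20000 nM in this assay, at which 3 of the 3 values shown sit.

The compounds shown leave open whether drawing the saturated ring carbon stereocentre S or R changes inhibition in this assay at all.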